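A few compounds are considered here, and "the series" means these few. Any claim that something is new, unique, unknown or untested is made for them only; others in the source may bear on it.

Compound 1 `O=C1OC[C@H](Cc2ccccc2)[C@H]1Cc1cccc(O)c1` carries a 3-hydroxyphenyl group. In a functional assay on HL-60 cells (Homo sapiens) for cytotoxicity, read by WST assay, with a stated time of 48 h (a lower number here means that less compound is needed, a higher number that more compound is needed for the effect), compound 1 gives only a limit, > 100000 nM, not a number (the limit of > 100000 nM in this assay, at which 1 of the 3 values shown sits). Compound 2 `COc1cccc(C[C@H]2C(=O)OC[C@@H]2Cc2ccccc2)c1`, with a methyl on that oxygen, gives 66000 nM in this assay. Compound 3 `CCCCOc1cccc(C[C@H]2C(=O)OC[C@@H]2Cc2ccccc2)c1`, with a butyl on that oxygen, gives 26000 nM in this assay. Compound 4 `Cc1ccc(C[C@H]2C(=O)OC[C@@H]2Cc2ccccc2)cc1` differs from compound 1 by 4-methylphenyl in place of 3-hydroxyphenyl on a saturated chain carbon bound to a saturated ring carbon, so the hydrogen-bond donor is gone altogether. Going by the values given here, the steps that bear on this are an at least 1.5-fold lower number from compound 1 to compound 2 (0.18 log units; that floor lies within the scatter) and an at least 3.8-fold lower number from compound 1 to compound 3 (0.58 log units; beyond the scatter): capping the hydroxyl lowered the number, at least modestly. Removing it is expected to act in the same direction, so compound 4 is estimated at 40000 nM in this assay, within a range of 15000 nM to 100000 nM, which would be the expected step of an at least 2.5-fold lower number from compound 1 to compound 4 (0.39 log units; beyond the scatter).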

Compound 4, half-maximal effective concentration: 44000 nM
Compound 4: middle estimate off by 1.1-fold (0.04 log units), on the low side; low and high end bracket the measured number.
By their numbers in this assay, from the lowest: compounds 3, 4 and 2 (each within the scatter of the next, the first and the last beyond it). At a limit, above all of these: compound 1.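

In this assay, replacing 3-hydroxyphenyl with 4-methylphenyl gives an at least 2.2-fold lower number from compound 1 to compound 4 (0.35 log units; beyond the scatter), so a measurable number does not depend on a capped oxygen: a group with 0 hydrogen-bond donors and 0 hydrogen-bond acceptors also gives one. Compound 4 lies within the scatter of compound 2 and of compound 3, so neither capped oxygen stands apart from it. Compound 1 remains a limit, not a number: the limit of > 100000 nM in this assay, at which 1 of the 4 values shown sits.

On these data alone, whether losing the hydroxyl or the different ring pattern carries this step stays open. So does what an amine or a carboxylic acid on this phenyl ring would give.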